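This account rests on a few compounds, and the source may have more. Where it says the series, first, only, none or still open, it means among the compounds named here.

In an ADME assay on a cell-free system (plasma, Homo sapiens) for metabolic stability, read by LC-MS (a higher number here means that the compound lasts longer, a lower number that the compound disappears faster), three compounds have been measured so far: compound 1 `CCCCOC(=O)c1cccc(-c2cc(C(=O)Nc3ccncc3)ccc2CN)c1` gives 0.367 h, and compound 2 `CCCOC(=O)c1cccc(-c2cc(C(=O)Nc3ccncc3F)ccc2CN)c1` gives 0.317 h. Compound 3 `NCc1ccc(C(=O)Nc2ccncc2F)cc1-c1cccc(C(=O)O)c1` reaches only a limit of the assay, > 2 h.

Compound 1 holds the higher of the two numbers, but compound 2 sits within the scatter of it, so the two cannot be told apart; compound 3 stands at the limit (the limit of > 2 h in this assay, at which 1 of the 3 values shown sits).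

Compound 4 `COC(=O)c1cccc(-c2cc(C(=O)Nc3ccncc3)ccc2CN)c1` differs from compound 1 in one place: hydrogen in place of propyl on a saturated chain carbon bound to an oxygen next to a carbonyl group. For the measured compounds named here, the only measured step that bears on this position is an at least 6.3-fold higher number from compound 2 to compound 3 (0.79 log units; beyond the scatter), where the whole alkyl leaves the oxygen and an acid remains. Going by the values given here, the change to compound 4 keeps an ester and merely shortens its chain, and no measured pair compares two esters of different length. Compound 4 is therefore expected to remain an ester of similar behaviour, with a step of a 1.1-fold higher number from compound 1 to compound 4 (0.04 log units; within the scatter) that stays within the scatter. Compound 4 is estimated at 0.4 h, between 0.15 h and 1.2 h.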

Compound 4, half-life: 1.52 h
Beside the measured number, compound 4's estimate is 3.8-fold (0.58 log units) below it, outside the stated range (above it).
By their numbers in this assay, from the lowest: compounds 2 and 1 (each within the scatter of the next); then compound 4. At a limit, above all of these: compound 3.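

In this assay, the ester no longer behaves as a single class at this position: going from butoxycarbonyl to methoxycarbonyl gives a 4.1-fold higher number from compound 1 to compound 4 (0.62 log units; beyond the scatter). The earlier compounds shown here showed a step beyond the scatter here only when the whole alkyl left the oxygen and a carboxylic acid remained, whereas this change keeps the ester and alters only the chain. Chain length on the ester oxygen therefore counts in its own right, although nothing shown here gives a cause for the step.

From the compounds shown here alone, an ethyl chain would show whether the number moves gradually or abruptly between butyl and methyl, and a branched chain such as isopropyl is also open. Going by these compounds, whether the same shortening holds in the fluorine-bearing compounds also remains open.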